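Alpha-substituent on the piperazine amide in an H2 series

A few compounds are considered here, and "the series" means these few. Any claim that something is new, unique, unknown or untested is made for them only; others in the source may bear on it.

Among the compounds with values here, the series shares one core, and the three measured members differ only in the group on the carbonyl carbon of the piperazine amide. Compound 1 `CC(C)(C)[C@@H](N)C(=O)N1CCN(CCCOc2ccc(C(=O)C3CC3)cc2)CC1` gives 19100 nM in an assay for binding affinity to histamine H2 receptor (Homo sapiens); a lower number here means a stronger inhibitor, a higher number a weaker inhibitor. Compound 2 `CCC[C@@H](N)C(=O)N1CCN(CCCOc2ccc(C(=O)C3CC3)cc2)CC1` gives 60300 nM in this assay. Compound 3 `NCCC(=O)N1CCN(CCCOc2ccc(C(=O)C3CC3)cc2)CC1` gives 100000 nM in this assay, the highest of the three numbers: its gap to compound 2 lies within the scatter, while its gap to compound 1 lies beyond it.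

Compound 4 `N[C@H](CC1CCCCC1)C(=O)N1CCN(CCCOc2ccc(C(=O)C3CC3)cc2)CC1` has not been measured. It differs from compound 3 in one place: 1-amino-2-cyclohexylethyl in place of 2-aminoethyl on a carbonyl carbon. Within the data shown here, two measured steps bear on this change. The step of a 5.2-fold higher number from compound 1 to compound 3 (0.72 log units; beyond the scatter) shows that removing a branched substituent on the carbon bound to the amine nitrogen and the carbonyl carbon raises the number; the step of a 1.7-fold higher number from compound 2 to compound 3 (0.22 log units; within the scatter) is within the scatter. Compound 4 reinstates a branched substituent at that carbon, larger than either the tert-butyl of compound 1 or the propyl of compound 2. A lower number than for compound 3 is therefore expected, of a size at least matching the reverse of the step from compound 1 to compound 3; the expected step is a 6.7-fold lower number from compound 3 to compound 4 (0.82 log units; beyond the scatter). The estimate for compound 4 is 15000 nM, with a range from 4000 nM to 50000 nM.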

Compound 4, inhibition constant: 20400 nM
Compound 4: the middle estimate sits 1.4-fold (0.13 log units) below what was measured; low and high end bracket the measured number.
By their numbers in this assay, from the lowest: compounds 1 and 4 (each within the scatter of the next); then compounds 2 and 3 (each within the scatter of the next).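

In this assay, a 4.9-fold lower number from compound 3 to compound 4 (0.69 log units; beyond the scatter), and a 3.0-fold lower number from compound 2 to compound 4 (0.47 log units; beyond the scatter), so the number at this position responds to a cyclohexyl-bearing substituent as well as to the tert-butyl of compound 1, and the response exceeds the scatter against both compound 2 and compound 3. With a 1.1-fold higher number from compound 1 to compound 4 (0.03 log units; within the scatter), the step from tert-butyl to cyclohexylmethyl lies within the scatter, so two substituents of different shape and size cannot be told apart here, and a larger group on this carbon does not continue to move the number. No measurement shown gives a reason for either the gain over compounds 2 and 3 or the match with compound 1.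

Going by these compounds, whether an aromatic ring can take the place of the saturated one remains open, as benzyl in place of cyclohexylmethyl would show, and so does the part played by the amine, which a hydroxyl group at the same carbon would test. The effect of the opposite configuration at the defined stereocentre of compound 4 is also unresolved, since no pair shown separates configuration from substituent.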